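Side-chain swap on the shared core: compound 2 to compound 3

This account rests on a few compounds, and the source may have more. Where it says the series, first, only, none or still open, it means among the compounds named here.

Measured so far:
Compound 1 `Nc1ccc2cccc(OCCC3CCCCC3)c2n1`: in an assay on cells with melanin-concentrating hormone receptor 1 (Homo sapiens) as the target, read by radioligand binding (a higher number here means a weaker inhibitor, a lower number a stronger inhibitor), compound 1 gives 808 nM.
Compound 2 `CC(C)OCCOc1cccc2ccc(N)nc12`: in this assay compound 2 reaches only a limit of the assay, > 2000 nM.

Compound 2 therefore stands at the limit (the limit of > 2000 nM in this assay, at which 1 of the 2 values shown sits), with no number of its own; only the measured step of an at least 2.4-fold higher number from compound 1 to compound 2 (0.39 log units; beyond the scatter) places it, and that step was at least modest and toward weaker binding.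

Compound 3 `CSCCOc1cccc2ccc(N)nc12` differs from compound 2 by methylsulfanyl in place of isopropoxy on a saturated chain carbon, two bonds along the chain from an oxygen on an aromatic ring. Going by the values given here, no measured step covers this change; the one step available replaces a different group at the same place and ran toward weaker binding from compound 1. With the starting point itself a limit, no step beyond the scatter is expected in this assay in either direction, and compound 3 is expected to stay in the region of the limit.

Estimate: compound 3 is expected at 3500 nM, in the range 1200 nM to 12000 nM. This estimate means an expected step that the limit leaves unreadable from compound 2 to compound 3.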

Compound 3, half-maximal inhibitory concentration: > 2000 nM
Compound 3 ended at the assay's limit; the forecaster's own chance of this, stated with the estimate: 70%; the middle value does not contradict the limit.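

In this assay, methylsulfanyl in place of cyclohexyl gives an at least 2.4-fold higher number from compound 1 to compound 3 (0.39 log units; beyond the scatter), so both replacements of cyclohexyl shown at this place run toward weaker binding. For compound 3 the value is only a limit of the assay, > 2000 nM. The step between compound 2 and compound 3 cannot be read, as both compounds stand at limits, so isopropoxy and methylsulfanyl cannot be ranked, and among the compounds shown only compound 1, with cyclohexyl, has a measured number.

As far as these compounds go, how far compound 2 and compound 3 lie past the limit stays open. Also open, from the compounds shown here alone, is whether a phenyl ring, a longer chain or an amine at this place would give a measurable number, and so whether the cyclohexyl ring itself matters or any large group would do.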